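The source may report more compounds than this note shows. Statements on the series, on what has been measured and on what is new or still open speak of the compounds shown alone.

Measured compounds:
- compound 1, `O=C(c1c(O)ccc2cc(-c3cccc(O)c3)ccc12)N1CCOCC1`, giving 62% in an in vitro assay on Sf9 cells for inhibition of 17-beta-hydroxysteroid dehydrogenase type 1 (Homo sapiens), tested at 1 uM; on this read-out higher numbers stand for a stronger effect at the one concentration tested and lower numbers for a weaker effect
- compound 2, `CNC(=O)c1c(O)ccc2cc(-c3cccc(O)c3)ccc12`, giving 76% in this assay
- compound 3, `O=C(/C=C/c1c(O)ccc2cc(-c3cccc(O)c3)ccc12)Nc1ccccc1`, giving 60% in this assay

Among these three, compound 2 stands highest; its nearest neighbour is compound 1, and the step of a number 14 percentage points higher from compound 1 to compound 2 (beyond the scatter) is the only single-change comparison available. Within the data shown here, compound 3, which carries a longer linker between the core and the amide nitrogen, gives a lower value than compound 2, but no single step connects the two.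

Compound 4, `CNC(=O)CCc1c(O)ccc2cc(-c3cccc(O)c3)ccc12`, is reached from compound 2 by 2-(methylcarbamoyl)ethyl in place of methylcarbamoyl on an aromatic carbon. Among the measured compounds shown here, no measured step describes a lengthening of this kind; the one known step concerns the amine on the carbonyl carbon, and it was of modest size. The only hint on chain length comes from the values of compound 2 and compound 3, which point downward for a longer linker, though that pair also differs at the amine. The expected change for compound 4 is therefore a modest fall, a number 11 percentage points lower from compound 2 to compound 4 (beyond the scatter), with the possibility that it stays within the scatter. Compound 4 is estimated at 65%, in the range 45% to 82%.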

Compound 4, a percentage reported as inhibition, at one concentration (the size of the read-out at that concentration, not a potency): 80%
Beside the measured number, compound 4's estimate is 15 percentage points below it, within the range that was stated.
By their numbers in this assay, from the lowest: compounds 3 and 1 (each within the scatter of the next); then compounds 2 and 4 (each within the scatter of the next).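

In this assay the exchange of methylcarbamoyl for 2-(methylcarbamoyl)ethyl, on the aromatic carbon ortho to a hydroxy group, is the first change shown that alters the chain at this position while keeping the methylamide, and it amounts to a number 4 percentage points higher from compound 2 to compound 4 (within the scatter); at the one concentration tested, this read-out does not separate the direct amide from the one carried on the 2-(methylcarbamoyl)ethyl chain. Set against the (morpholin-4-yl)carbonyl group at the same place, the new chain gives a number 18 percentage points higher from compound 1 to compound 4 (beyond the scatter), which stands alongside the earlier step of a number 14 percentage points higher from compound 1 to compound 2 (beyond the scatter) and shows that both methylamide groups read clear of the morpholine amide in these compounds. No measurement available here speaks to why the chain makes so little difference at this position.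

The compounds shown leave open whether the same holds for a still longer chain, such as a 3-(methylcarbamoyl)propyl group, or for a terminal carboxylic acid or a morpholine amide on the 2-carbon chain. They also leave open whether compound 2 and compound 4 would differ in a full concentration series, which a single-concentration read-out cannot show.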